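Chlorine position on the benzyl ether: compound 4

The source may report more compounds than this note shows. Statements on the series, on what has been measured and on what is new or still open speak of the compounds shown alone.

Measured so far:
compound 1 `O=C(O)c1nn(Cc2cc(Br)ccc2OCc2ccccc2)cc1F` gives 123 nM
compound 2 `O=C(O)c1nn(Cc2cc(Br)ccc2OCc2ccccc2)cc1C(F)(F)F` gives 2570 nM
compound 3 `Cc1cc(C(=O)O)nn1Cc1cc(Br)ccc1OCc1ccc(Cl)cc1` gives 8.71 nM

All numbers come from an assay on CHO-K1 cells for displacement of a labelled ligand from prostaglandin E2 receptor EP1 subtype (Homo sapiens); a higher number here means a weaker inhibitor, a lower number a stronger inhibitor. Compound 3 gives the lowest number of the three; compound 1 stands nearest and compound 2 furthest, both gaps lying beyond the scatter. Among the compounds with values here, the only step between measured compounds that differ in one place, a 21-fold higher number from compound 1 to compound 2 (1.32 log units; beyond the scatter), concerns the substituent on the shared core and does not touch the benzyl ether. Compound 4 `Cc1cc(C(=O)O)nn1Cc1cc(Br)ccc1OCc1cccc(Cl)c1` differs from compound 3 only there: 3-chlorophenyl in place of 4-chlorophenyl on a saturated chain carbon bound to an oxygen on an aromatic ring. Within the data shown here, no measured pair bears on this change, so nothing in this assay speaks to the size or direction of the step; the expectation rests on the change being a rearrangement within the same group. The step is estimated to be small, within or close to the scatter: a 1.7-fold higher number from compound 3 to compound 4 (0.24 log units; within the scatter). Compound 4 is accordingly expected to give about 15 nM, with a range of 5 nM to 50 nM.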

Compound 4, half-maximal inhibitory concentration: 115 nM
Beside the measured number, compound 4's estimate is 7.7-fold (0.88 log units) below it, outside the stated range (above it).
By their numbers in this assay, from the lowest: compound 3; then compounds 4 and 1 (each within the scatter of the next); then compound 2.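

In this assay, moving the chlorine within the benzyl ether is not a neutral rearrangement: 3-chlorophenyl in place of 4-chlorophenyl gives a 13-fold higher number from compound 3 to compound 4 (1.12 log units; beyond the scatter). Within the data shown here, the one earlier step changed a substituent on the shared core and left the benzyl ether untouched, so this is the first measured sign that the aryl group on the saturated chain carbon bound to an oxygen on an aromatic ring also shifts the number. The two compounds hold the same atoms, joined differently, so the location of the chlorine alone is enough to produce a large step here.

Still open, from the compounds shown here alone, is how a plain phenyl, or a fluorine or methyl group in place of the chlorine, would read on this core. Also open, going by these compounds, is whether the same chlorine move gives a step of similar size on the core of compound 1. No measurement available here accounts for the size or direction of this step.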